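A few compounds are considered here, and "the series" means these few. Any claim that something is new, unique, unknown or untested is made for them only; others in the source may bear on it.

Compound 3 `CN(C)C/C=C/C(=O)Nc1cccc(Nc2nc(N/N=C/c3c[nH]c4ccccc34)ncc2Cl)c1` gives 9680 nM in an ADME assay on HT-29 cells (Homo sapiens) for inhibition, read by MTT assay, with a stated time of 72 h (on this read-out lower numbers stand for stronger inhibition and higher numbers for weaker inhibition), the highest of the three numbers measured. Compound 1 `CN(C)C/C=C/C(=O)Nc1cccc(Nc2nc(N/N=C/c3ccc(F)cc3)ncc2Cl)c1` gives 3300 nM in this assay, and the step of a 2.9-fold higher number from compound 1 to compound 3 (0.47 log units; beyond the scatter) is a modest one, beyond the scatter. Compound 2 `COc1ccc(/C=N/Nc2ncc(Cl)c(Nc3cccc(NC(=O)/C=C/CN(C)C)c3)n2)cc1` gives 4820 nM in this assay, and the step of a 2.0-fold higher number from compound 2 to compound 3 (0.30 log units; within the scatter) stays within the scatter, as does the step of a 1.5-fold higher number from compound 1 to compound 2 (0.16 log units; within the scatter).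

Compound 4 `COc1ccc(/C(C)=N/Nc2ncc(Cl)c(Nc3cccc(NC(=O)/C=C/CN(C)C)c3)n2)cc1` differs from compound 3 in one place: a group of 11 heavy atoms (9 carbon, 1 nitrogen, 1 oxygen; one six-membered aromatic ring of carbon only) in place of a group of 11 heavy atoms (9 carbon, 2 nitrogen; one five-membered aromatic ring with 1 hetero atom, one six-membered aromatic ring of carbon only), on a nitrogen on an aromatic ring. The hydrazone in compound 4 carries the same methoxyphenyl ring as compound 2 but with an added methyl on the carbon double-bonded to nitrogen. Going by the values given here, the only measured step that bears on this change is a 2.0-fold higher number from compound 2 to compound 3 (0.30 log units; within the scatter), which, run in reverse, points to a somewhat lower number; no measured pair speaks to the added methyl, so that part of the change is uncertain. Compound 4 is therefore expected to sit near compound 2, with the estimated step of a 1.9-fold lower number from compound 3 to compound 4 (0.29 log units; within the scatter) being small. The estimate for compound 4 in this assay is 5000 nM, in a range from 1500 nM to 16000 nM.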

Compound 4, half-maximal inhibitory concentration: 6830 nM
The estimate for compound 4 lay 1.4-fold (0.14 log units) below the measured number; measured number inside the range.
By their numbers in this assay, from the lowest: compounds 1, 2, 4 and 3 (each within the scatter of the next, the first and the last beyond it).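

In this assay, going by these compounds alone, the methyl on the carbon double-bonded to nitrogen, which no earlier compound carried, leaves the methoxyphenyl hydrazone within the scatter of its parent (a 1.4-fold higher number from compound 2 to compound 4 (0.15 log units; within the scatter)). The exchange of the 1H-indol-3-yl hydrazone for this methylated group also stays within the scatter (a 1.4-fold lower number from compound 3 to compound 4 (0.15 log units; within the scatter)), whereas the comparison with the 4-fluorophenyl hydrazone is a modest step beyond it (a 2.1-fold higher number from compound 1 to compound 4 (0.32 log units; beyond the scatter)). Nothing available accounts for these differences.

As far as these compounds go, the reading on the added methyl rests on a single pair, so whether it holds on the 4-fluorophenyl or 1H-indol-3-yl hydrazones remains open. Also open, from the compounds shown here alone, is how an ethyl in place of that methyl, or an amine or a carboxylic acid on the aromatic ring, would read in this assay.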